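Replacing Ethyl with 4-Methoxyphenyl: An Expected Gain

The compounds below may be only part of what the source reports. "The series", "measured", "known", "first", "only" and "open" are said of these compounds alone.

Three compounds have been measured so far:
compound 1 `O=C(O)Cc1sc(C(c2ccccc2)c2ccccc2)nc1-c1ccccc1` gives 80%
compound 2 `CCC(c1ccccc1)c1nc(-c2ccc(Cl)cc2)c(CC(=O)O)s1` gives 50%
compound 3 `O=C(O)Cc1sc(C(c2ccccc2)c2ccc(F)c(F)c2)nc1-c1ccc(F)cc1` gives 80%

All three were tested in an in vitro functional assay on HEK285-7 cells for antagonist activity at prostaglandin D2 receptor 2 (Homo sapiens), read by BRET and beta-arrestin recruitment; on this read-out higher numbers stand for larger maximal responses and lower numbers for smaller maximal responses. On these numbers compound 2 stands lowest. Its nearest neighbour is compound 1, whose value lies higher by a margin that exceeds the usual scatter, and compound 3 sits at the same higher level, so compound 2 is clearly set apart from both.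

Compound 4 `COc1ccc(C(c2ccccc2)c2nc(-c3ccc(Cl)cc3)c(CC(=O)O)s2)cc1` has not been measured yet. It differs from compound 2 in a single place: 4-methoxyphenyl in place of ethyl on a saturated chain carbon bound to two aromatic carbons. In compound 1 and compound 3, which both give the higher values, the saturated chain carbon carries two aromatic rings, whereas compound 2 carries an ethyl group there. For the measured compounds named here, compound 4 again carries two aromatic rings on that carbon, so a rise is expected, and it is expected to be larger than the scatter, although the methoxy group on the new ring has no precedent among the measured compounds.

Because compound 1 gives 80% and compound 3 gives 80%, the estimated step from compound 2 to compound 4 is a number 25 percentage points higher from compound 2 to compound 4 (beyond the scatter). Compound 4 is therefore expected to reach about 75%, with a likely range from 55% to 90%.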

Compound 4, largest response reached (reported as efficacy), in percent of the reference or control that the assay uses: 80%
Compound 4: the middle estimate sits 5 percentage points below what was measured; low and high end bracket the measured number.
By their numbers in this assay, from the lowest: compound 2; then compounds 1, 3 and 4 (each within the scatter of the next).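

In this assay, for the compounds shown here, the swap of ethyl for 4-methoxyphenyl on a saturated chain carbon bound to two aromatic carbons gives a number 30 percentage points higher from compound 2 to compound 4 (beyond the scatter) and so ties the higher number to this one place for the first time. Compound 1 and compound 3 also carry two aromatic rings on that carbon, but they differ from compound 2 in other places as well, so they could not separate this change from the others, whereas compound 2 and compound 4 differ only here. The rise also shows that a methoxy group on the new ring, which none of the earlier compounds carries, still goes together with a higher maximal response, although nothing measured here explains why the response changes with this swap.

The compounds shown do not tell whether the added aromatic ring alone accounts for the step or whether the methoxy group contributes to it. They also leave open how this carbon would respond to a cyclohexyl ring, a butyl chain or an amine in place of ethyl, which would show whether an aromatic ring is needed there at all.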